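Phenyl in place of trifluoromethyl in compound 1

The compounds below may be only part of what the source reports. "The series", "measured", "known", "first", "only" and "open" are said of these compounds alone.

Compound 1 `C/C(=N/O)c1ccc(NC(=O)Cn2nc(C(F)(F)F)nc2N)cc1`: 11.9%
Compound 2 `COc1cc(-c2nc3sc(-c4ccccc4)cn3n2)cc(OC)c1OC`: 18%

Both values come from a functional assay on HT-29 cells (Homo sapiens) for inhibition, read by sulforhodamine B assay, with a stated time of 48 h, tested at 10 uM; on this read-out higher numbers stand for more inhibition of growth at the one concentration tested and lower numbers for less inhibition of growth. There, compound 1 stands within the usual scatter of compound 2, so the two numbers cannot be told apart, and neither compound shows much inhibition of growth. For the measured compounds named here, the structures of these two compounds have little in common, and no measured pair yet isolates a single change.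

Compound 3 `C/C(=N/O)c1ccc(NC(=O)Cn2nc(-c3ccccc3)nc2N)cc1` keeps the rest of compound 1 and carries phenyl in place of trifluoromethyl on an aromatic carbon. Going by the values given here, the only guides are compound 1 at 11.9% and compound 2 at 18%, so only a small upward move, not beyond the scatter, is expected in this assay. The expected size of the change is a number 3.1 percentage points higher from compound 1 to compound 3 (within the scatter). The estimated value for compound 3 is 15%, with an expected range from 2% to 32%.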

Compound 3, percent growth inhibition at one concentration: 13.9%
The estimate for compound 3 lay 1.1 percentage points above the measured number; low and high end bracket the measured number.
By their numbers in this assay, from the lowest: compounds 1, 3 and 2 (each within the scatter of the next).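

In this assay, for the compounds shown here, this is the first pair that differs in one place, and it gives a number 2 percentage points higher from compound 1 to compound 3 (within the scatter). On this aromatic carbon, between two ring nitrogen atoms, trifluoromethyl and phenyl therefore cannot be told apart, even though phenyl brings a six-membered aromatic ring and more heavy atoms. Neither compound shows much inhibition of growth, and nothing given here bears on why these numbers are so close.

As far as these compounds go, it remains open whether a quite different group at this carbon, such as a carboxylic acid or a short alkyl chain, would move the number beyond the scatter. Also open, from the compounds shown here alone, is whether the same swap would read the same way on a compound that inhibits growth more strongly.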